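This account rests on a few compounds, and the source may have more. Where it says the series, first, only, none or still open, it means among the compounds named here.

Measured compounds:
Compound 1, `C[C@@H]1CC[C@@H](Oc2cc(Br)ccn2)CN1C(=O)c1ccccc1-n1nccn1`: 380 nM
Compound 2, `CC(C)OC(=O)c1ccccc1C(=O)N1C[C@H](Oc2cc(C#N)ccn2)CC[C@H]1C`: 3300 nM

In a functional assay on CHO-K1 cells for antagonist activity at Orexin/Hypocretin receptor type 1 (Homo sapiens), read by FLIPR and calcium flux (a lower number here means a stronger inhibitor, a higher number a weaker inhibitor), compound 1 gives the lower of the two numbers, and compound 2 gives a number that is well beyond the scatter above it. Compound 3, `CCc1ccnc(O[C@@H]2CC[C@@H](C)N(C(=O)c3ccccc3-n3nccn3)C2)c1`, is not yet measured. It differs from compound 1 in one place: ethyl in place of bromo on an aromatic carbon. Within the data shown here, no measured pair shows this change, so the step from compound 1 to compound 3 is expected to be small, with neither direction clearly favored, roughly a 1.3-fold higher number from compound 1 to compound 3 (0.12 log units; within the scatter). Compound 3 is therefore estimated at 500 nM, within a range of 180 nM to 1500 nM.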

Compound 3, half-maximal inhibitory concentration: 310 nM
Estimate against measurement, compound 3: 1.6-fold (0.21 log units) above, within the range that was stated.
By their numbers in this assay, from the lowest: compounds 3 and 1 (each within the scatter of the next); then compound 2.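

Ethyl in place of bromo, opposite the ring nitrogen, gives a 1.2-fold lower number from compound 1 to compound 3 (0.09 log units; within the scatter) in this assay. This position therefore accepts either group with no change beyond the scatter, which compounds 1 and 2 could not show, as they differ in more than one place. No evidence at hand explains why the two groups read alike. Still open, as far as these compounds go, is how a longer chain, an amine or a carboxylic acid would read at this position. So is how much of the gap to compound 2 belongs to its nitrile.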